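Compound 4: hydrogen in place of hydroxy

A few compounds are considered here, and "the series" means these few. Any claim that something is new, unique, unknown or untested is made for them only; others in the source may bear on it.

Compound 1 `CCc1cc(CCCOc2c(C)cc(-c3noc(C4CC4)n3)cc2C)on1`: 0.9 h
Compound 2 `Cc1cc(-c2noc(C3CC3)n2)cc(C)c1OCCCc1cc(C2CC2)no1`: > 2.5 h
Compound 3 `Cc1cc(-c2noc(C3CC3)n2)cc(C)c1OCCCc1cc(OCCO)no1`: > 2.5 h

In an in vitro ADME assay on microsomes from liver (Simiiformes) (a lower number here means that the compound disappears faster, a higher number that the compound lasts longer), compound 3 gives > 2.5 h, which is a limit and not a number. Compound 4 `CCOc1cc(CCCOc2c(C)cc(-c3noc(C4CC4)n3)cc2C)on1` differs from compound 3 by hydrogen in place of hydroxy on a saturated chain carbon, two bonds along the chain from an oxygen on an aromatic ring, so 2-hydroxyethoxy becomes ethoxy. The closest guide is an at least 2.7-fold higher number from compound 1 to compound 3 (0.44 log units; beyond the scatter), as compound 1 carries ethyl and no hydroxy. Against a simple hydroxy rule stands an at least 2.7-fold higher number from compound 1 to compound 2 (0.44 log units; beyond the scatter), reached with cyclopropyl and no hydroxy. A fall of similar size is therefore expected in this assay, though with real uncertainty. The expected change is an at least 1.9-fold lower number from compound 3 to compound 4 (0.28 log units; that floor lies within the scatter). The estimate for compound 4 is 1.3 h, with an expected range from 0.6 h to 2.5 h.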

Compound 4, half-life: > 2.5 h
Compound 4 gave a limit, no number (the forecaster's own chance of this, stated with the estimate: 20%); middle value at least 1.9-fold (0.28 log units) away from the limit.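

In this assay, ethoxy in place of ethyl on an aromatic carbon gives an at least 2.7-fold higher number from compound 1 to compound 4 (0.44 log units; beyond the scatter), so the hydroxy of 2-hydroxyethoxy is not needed to rise beyond compound 1. Compound 4 gives > 2.5 h, which is a limit and not a number. The steps among compound 2, compound 3 and compound 4 cannot be read because all three sit at one limit: the limit of > 2.5 h in this assay, at which 3 of the 4 values shown sit.

On these data alone, how far these three groups truly differ therefore stays open. So does the outcome with an amine or a carboxylic acid at the end of this chain.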